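The source may report more compounds than this note shows. Statements on the series, on what has been measured and on what is new or still open speak of the compounds shown alone.

Compound 2 `CCCc1ccc(C(=O)N[C@@H](CC(C)C)C(=O)NCCNc2ccc(OC)cc2)cc1` stands at the lowest of the two numbers measured in an assay on isolated protein for inhibition of cathepsin S (Homo sapiens), read by fluorescence (on this read-out higher numbers stand for weaker inhibition and lower numbers for stronger inhibition), where compound 2 gives 1200 nM. Within the data shown here, its only neighbour with a number is compound 1 `COc1ccc(NCCNC(=O)[C@H](CC(C)C)NC(=O)c2ccc(OCc3ccccc3)cc2)cc1`, which in this assay gives 9500 nM; the single step between them, a 7.9-fold lower number from compound 1 to compound 2 (0.90 log units; beyond the scatter), came from putting propyl in place of benzyloxy on an aromatic carbon. Compound 3 `COc1ccc(NCCNC(=O)[C@H](CC(C)C)NC(=O)c2ccc(C(C)C)cc2)cc1` has not yet been measured in this assay. It differs from compound 2 in one place: isopropyl in place of propyl on an aromatic carbon. Among the measured compounds shown here, no measured step bears directly on this change; the one step available, a 7.9-fold lower number from compound 1 to compound 2 (0.90 log units; beyond the scatter), swapped a group of quite different size and does not tell how a rearrangement of the same three carbons would read. The two compounds share every other part of the structure, so the step is expected to be small, most likely none beyond the scatter, in this assay. Compound 3 is therefore estimated to give 1200 nM, within 500 nM to 3000 nM, in this assay. The expected step from compound 2 is no change at the digits printed from compound 2 to compound 3 (within the scatter).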

Compound 3, half-maximal inhibitory concentration: 5700 nM
Estimate against measurement, compound 3: 4.8-fold (0.68 log units) below; measured number outside the range, above it.
By their numbers in this assay, from the lowest: compound 2; then compounds 3 and 1 (each within the scatter of the next).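

The swap of propyl for isopropyl keeps the same atoms, joined differently, yet it gives a 4.8-fold higher number from compound 2 to compound 3 (0.68 log units; beyond the scatter) in this assay and so shows that the number at this position, para to a large group, depends on how the three carbons are joined and not only on how many there are. Among these compounds, the earlier step had exchanged groups of quite different size, whereas isopropyl and benzyloxy, for all that difference, give a 1.7-fold lower number from compound 1 to compound 3 (0.22 log units; within the scatter) and leave propyl in compound 2 as the only one of the three groups whose steps to both others lie beyond the scatter. Nothing available explains why the two arrangements of the same carbons read so differently.

On these data alone, whether a longer straight chain such as butyl or pentyl would hold or lower the number of compound 2 remains open, and so does whether a branched group such as tert-butyl or a ring such as cyclopropyl would read like isopropyl. As far as these compounds go, with only these three groups at this one position, it also remains open how an amine or a carboxylic acid would read there.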